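Two diaryl-linked quinoxalines and one swap of a phenyl ring

The compounds below may be only part of what the source reports. "The series", "measured", "known", "first", "only" and "open" are said of these compounds alone.

The compounds here share the core of compound 1 `Nc1cc(N)c2nc(-c3ccccc3)c(NCc3ccc(Cl)c(Cl)c3)nc2c1`, and are compared in a functional assay on 786-0 cells (Homo sapiens) for inhibition, read by sulforhodamine B assay, with a stated time of 48 h; a lower number here means a stronger inhibitor of growth, a higher number a weaker inhibitor of growth. Compound 1 gives 30200 nM in this assay. Compound 2 `Nc1cc(N)c2nc(-c3ccccc3)c(Sc3ccc(F)cc3)nc2c1` carries a sulfur linker instead of the aminomethyl bridge of compound 1, and its result is a limit of the assay rather than a number: compound 2 gives < 100000 nM in this assay. That limit is described as the limit of < 100000 nM in this assay, at which 1 of the 2 values shown sits, so it marks only an edge of the measured range, and compound 2 stands at that edge among the values shown.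

Compound 3 `Nc1cc(N)c2nc(-c3ccccc3)c(Sc3ccc(Cl)c(Cl)c3)nc2c1` has not yet been tested. It differs from compound 2 in one place: 3,4-dichlorophenyl in place of 4-fluorophenyl on a sulfur. For the measured compounds named here, the same 3,4-dichlorophenyl group appears in compound 1, though there it sits on an aminomethyl bridge rather than on a sulfur, and no measured step connects the two linkers directly.

Going by the values given here, with no measured step to lean on, the expected change from compound 2 to compound 3 is a step that the limit leaves unreadable from compound 2 to compound 3, a modest gain in this assay rather than none. Compound 3 is therefore estimated at 35000 nM, within a range from 10000 nM to 100000 nM, a figure that may itself come back only as a limit.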

Compound 3, concentration for total growth inhibition: 61700 nM
Beside the measured number, compound 3's estimate is 1.8-fold (0.25 log units) below it, and the stated range covers the measured number.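

No step can be read from compound 2 to compound 3, because compound 2 is known only as a limit of the assay and not as a number: the limit of < 100000 nM in this assay, at which 1 of the 3 values shown sits.

What the compounds shown leave open is whether 3,4-dichlorophenyl in place of 4-fluorophenyl on a sulfur changes the result in this assay at all, and in which direction.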